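The compounds below may be only part of what the source reports. "The series", "measured", "known", "first", "only" and "open" are said of these compounds alone.

Working notes on the azetidine amide series.

Compound 2, `O=C([C@H]1CC2CCC1C2)N1CC(c2nc(-c3ccccc3)no2)C1`, is the reference point of this step. In an assay on HEK293 cells for positive allosteric modulation of metabotropic glutamate receptor 5 (Homo sapiens), read by FLIPR (a higher number here means that more compound is needed for the effect, a lower number that less compound is needed), compound 2 gives 120 nM, the lowest of the two numbers in hand, though the gap to its nearest neighbour is within the scatter. That neighbour is compound 1, `O=C(C1CCC(F)(F)CC1)N1CC(c2nc(-c3cccc(Cl)c3)no2)C1`, which carries a different acyl group and a chloro substituent on the aryl ring; in this assay compound 1 gives 180 nM. The third member, compound 3, `Cc1ccc(S(=O)(=O)N2CC(c3nc(-c4cccc(C)c4)no3)C2)cc1`, is a sulfonamide rather than an amide; in this assay compound 3 returns only a limit, > 10000 nM, which is the situation recorded as the limit of > 10000 nM in this assay, at which 1 of the 3 values shown sits.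

Going by the values given here, no pair of measured compounds differs in a single place, so no measured step is available to lean on. The next compound, compound 4, `O=C([C@H]1CC2CCC1C2)N1CC(c2nc(-c3cccc(F)c3)no2)C1`, keeps the acyl group of compound 2 and changes only the aryl ring: fluoro in place of hydrogen on an aromatic carbon.

Given that compound 1 with its substituted aryl ring gives 180 nM, close to compound 2, the expectation is that the change to compound 4 moves the number little, in no firm direction, and not beyond the scatter. Compound 4 is estimated at 100 nM in this assay, within 40 nM to 300 nM, which means an expected step of a 1.2-fold lower number from compound 2 to compound 4 (0.08 log units; within the scatter).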

Compound 4, half-maximal effective concentration: 72 nM
Compound 4: the middle estimate sits 1.4-fold (0.14 log units) above what was measured, and the stated range covers the measured number.
By their numbers in this assay, from the lowest: compounds 4, 2 and 1 (each within the scatter of the next, the first and the last beyond it). At a limit, above all of these: compound 3.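

Going by these compounds alone, this is the first change that can be read at a single place: with the acyl group held fixed, phenyl to 3-fluorophenyl gives a 1.7-fold lower number from compound 2 to compound 4 (0.22 log units; within the scatter) in this assay. The step shows that a fluoro on this aromatic carbon leaves compound 2 and compound 4 within the scatter of each other, so the change can be recorded as compatible with a response in this range, but no gain can be claimed for it. Nothing in hand bears on the size of this step.

On these data alone, whether a trifluoromethyl, a nitrile or a methoxy group on the same aromatic carbon, with the same acyl group, would give a number beyond the scatter from compound 2 stays open. Steps from compound 1 or compound 3 to the other compounds cannot be read, as each differs from them in more than one place, so the separate roles of the acyl group, the chloro and the sulfonamide remain unresolved.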